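Moving the chlorine on the aryl group

This account rests on a few compounds, and the source may have more. Where it says the series, first, only, none or still open, it means among the compounds named here.

Values in a functional assay on B16 cells (Mus musculus) for cytotoxicity, read by CCK-8 assay, with a stated time of 24 h; a lower number here means a stronger inhibitor, a higher number a weaker inhibitor:
compound 1 `COc1ccccc1Oc1c(N)nc(Cc2ccccc2)nc1OCCO`: 47400 nM
compound 2 `COc1ccccc1Oc1c(N)nc(-c2cccc(Cl)c2)nc1OCCO`: 5010 nM
compound 3 `COc1ccccc1Oc1c(N)nc(-c2ccc(Cl)cc2)nc1OCCO`: not yet measured

Among the measured compounds shown here, compound 2 holds the lower of the two numbers so far, at 5010 nM, clearly apart from compound 1 at 47400 nM. Compound 3 differs from it as follows: 4-chlorophenyl in place of 3-chlorophenyl on an aromatic carbon. In words, 4-chlorophenyl stands in place of 3-chlorophenyl on an aromatic carbon, at a place between two ring nitrogen atoms and para to a 2-methoxyphenoxy group.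

For the measured compounds named here, only one measured step bears on this change: a 9.5-fold lower number from compound 1 to compound 2 (0.98 log units; beyond the scatter). It is modest but beyond the scatter, and it came from 3-chlorophenyl replacing benzyl, a different exchange from the one here. Going by the values given here, no measured pair shows what moving the chlorine does, so the data favour no direction. A shift within the scatter in this assay is the expectation, with a range wide enough to allow a step of the size seen from benzyl to 3-chlorophenyl. The expected step is a 1.0-fold lower number from compound 2 to compound 3 (0.00 log units; within the scatter). Compound 3 is estimated at 5000 nM, with an expected range of 2000 nM to 13000 nM.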

Compound 3, half-maximal inhibitory concentration: 7740 nM
Beside the measured number, compound 3's estimate is 1.5-fold (0.19 log units) below it; measured number inside the range.
By their numbers in this assay, from the lowest: compounds 2 and 3 (each within the scatter of the next); then compound 1.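

In this assay, moving the chlorine from 3-chlorophenyl to 4-chlorophenyl gives a 1.5-fold higher number from compound 2 to compound 3 (0.19 log units; within the scatter) at this aromatic carbon between two ring nitrogen atoms, so the two chlorine placements are not told apart here. The advantage over benzyl is therefore not confined to 3-chlorophenyl: the exchange of benzyl for 4-chlorophenyl gives a 6.1-fold lower number from compound 1 to compound 3 (0.79 log units; beyond the scatter) and so stands apart from the scatter as well, which gives two chlorophenyl examples rather than one. No measured evidence accompanies these numbers to explain either step.

Each exchange from benzyl changes both the group attached to the shared core and the presence of chlorine, so an unsubstituted phenyl group at this position would be needed to separate the two contributions. Going by these compounds, whether this position also accepts a group other than chlorophenyl, such as a methoxyphenyl, an aminophenyl or a carboxylic acid on the aryl ring, stays open, as does whether any such group would move the number beyond the scatter of the two chlorophenyl compounds.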